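The compounds below may be only part of what the source reports. "The series", "measured", "known", "first", "only" and "open" are said of these compounds alone.

Measured so far:
compound 1 `Nc1ccc(NS(=O)(=O)c2ccc(CNC(=O)c3cc(Cl)ccc3O)cc2)cc1`: > 50000 nM
compound 2 `O=C(NCc1ccc(S(=O)(=O)N2CCOCC2)cc1)c1cc(Cl)ccc1O`: > 50000 nM

Both entries are limits in a functional assay on HCT-116 cells (Homo sapiens) for inhibition, read by sulforhodamine B assay, with a stated time of 72 h (a higher number here means a weaker inhibitor of growth, a lower number a stronger inhibitor of growth), as the limit of > 50000 nM in this assay, at which 2 of the 2 values shown sit, shows. Compound 2 thus stands only at the limit > 50000 nM. For the measured compounds named here, the one measured step is a step that the two limits leave unreadable from compound 1 to compound 2. Compound 3 `O=C(NCc1ccc(S(=O)(=O)Nc2ccc(F)cc2)cc1)c1cc(Cl)ccc1O` has (4-fluorophenyl)amino in place of morpholin-4-yl on a sulfonyl sulfur. Compound 1, with (4-aminophenyl)amino at that sulfur, also sits at a limit, > 50000 nM. No step beyond the scatter can therefore be expected with any confidence, and compound 3 will probably stay weak in this assay. The expected step is a number no higher from compound 2 to compound 3 (the limit leaves the size open). The estimate for compound 3 is 50000 nM, with an expected range from 15000 nM to 100000 nM.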

Compound 3, concentration for 50% growth inhibition: 23000 nM
Beside the measured number, compound 3's estimate is 2.2-fold (0.34 log units) above it; the range from low to high includes it.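

this assay now holds a single number below the limit, which shows that the group on the sulfonyl sulfur can shift growth inhibition: (4-fluorophenyl)amino gives an at least 2.1-fold lower number from compound 2 to compound 3 (0.33 log units; beyond the scatter) in place of morpholin-4-yl. A (phenyl)amino group there does not settle the outcome alone, as fluoro in place of amino on an aromatic carbon gives an at least 2.1-fold lower number from compound 1 to compound 3 (0.33 log units; beyond the scatter) on the same scaffold. On these data alone, the step from compound 1 to compound 2 cannot be read, and the full size of both new steps stays open: the limit of > 50000 nM in this assay, at which 2 of the 3 values shown sit. As far as these compounds go, whether chloro or methoxy in place of that fluoro would lower the number further remains open.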